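Thiosemicarbazone series: fluorinated aryl groups on the terminal nitrogen

The source may hold more compounds than are shown below. What is called first, only, known or untested is meant among the compounds shown, and "the series" means these compounds.

Compound 1 `O=C1Nc2ccc(F)cc2/C1=N/NC(=S)Nc1ccccc1` is the parent of this pair. In a functional assay on the whole organism for inhibition, with Lemna aequinoctialis as the target, with a stated time of 7 days, tested at 500 ug/mL (on this read-out lower numbers stand for less inhibition of growth and higher numbers for more inhibition of growth at the one concentration tested), compound 1 gives 70%, the higher of the two numbers at hand. For the measured compounds named here, compound 2 `O=C1Nc2ccc(F)cc2/C1=N/NC(=S)Nc1ccc(OC(F)(F)F)cc1` carries trifluoromethoxy in place of hydrogen on an aromatic carbon, and in this assay compound 2 gives 35%; the step of a number 35 percentage points lower from compound 1 to compound 2 (beyond the scatter) is the only measured change and points downward. Compound 3 `O=C1Nc2ccc(F)cc2/C1=N/NC(=S)Nc1c(F)cccc1F` is not yet measured. Its difference from compound 1 is 2,6-difluorophenyl in place of phenyl on an amide-type nitrogen. Going by the values given here, no measured step touches this exact exchange; the single step from compound 1 to compound 2 shows only that the one substitution on the phenyl seen so far lowered growth inhibition by a large amount. On that basis a downward step of moderate size is expected, a number 20 percentage points lower from compound 1 to compound 3 (beyond the scatter), with wide uncertainty. For compound 3 the estimate in this assay is 50%, between 25% and 75%.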

Compound 3, percent growth inhibition at one concentration: 30%
Compound 3: middle estimate off by 20 percentage points, on the high side, and the stated range covers the measured number.
By their numbers in this assay, from the lowest: compounds 3 and 2 (each within the scatter of the next); then compound 1.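

In this assay the exchange of phenyl for 2,6-difluorophenyl on the amide-type nitrogen gives a number 40 percentage points lower from compound 1 to compound 3 (beyond the scatter) and so adds a second substitution pattern on this aryl group that comes with a large loss of growth inhibition. Read with a number 35 percentage points lower from compound 1 to compound 2 (beyond the scatter) in this assay, both substituted aryl groups shown stand lower than plain phenyl, and no compound shown goes against this. Nothing at hand gives a reason for the drop.

As far as these compounds go, whether a single fluorine on the phenyl, or a methyl, methoxy or amino group there, keeps the growth inhibition of the parent remains open. Also open, from the compounds shown here alone, is how a butyl chain or a cyclohexyl group in place of the phenyl would read out.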